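Urea replacement at the anilide nitrogen of compound 3

The source may report more compounds than this note shows. Statements on the series, on what has been measured and on what is new or still open speak of the compounds shown alone.

Measured compounds and their values:
compound 1, `O=C(Nc1ccc(Cl)cc1)Nc1ccc(Oc2ccc(-c3nccs3)cc2)cc1`, 17.7%
compound 2, `O=C(Nc1ccc(Oc2ccc(-c3nccs3)cc2)cc1)Nc1cc(C(F)(F)F)ccc1Cl`, 75.5%
compound 3, `O=C(Nc1ccc(Cl)cc1)Nc1ccc(Oc2ccc(-c3ncc[nH]3)cc2)cc1`, 8.86%

Three ureas sharing one core have been tested in a functional assay on A549 cells (Homo sapiens) for inhibition, read by MTT assay and WST assay, with a stated time of 72 h, tested at 10 uM; on this read-out higher numbers stand for more inhibition of growth at the one concentration tested and lower numbers for less inhibition of growth. Compound 3 gives 8.86%, the lowest of the three numbers; its nearest neighbour is compound 1, and the gap between them is a number 8.8 percentage points lower from compound 1 to compound 3 (within the scatter), so the two stand level. Compound 2 lies far above both, as a number 57.8 percentage points higher from compound 1 to compound 2 (beyond the scatter) shows.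

The new compound 4, `CC(=O)Oc1sccc1NC(=O)Nc1ccc(Oc2ccc(-c3ncc[nH]3)cc2)cc1`, differs from compound 3 in one place: 2-acetoxythiophen-3-yl in place of 4-chlorophenyl on an amide-type nitrogen. For the measured compounds named here, the only measured step at that same nitrogen is a number 57.8 percentage points higher from compound 1 to compound 2 (beyond the scatter), which shows that an exchange of the group on this nitrogen can move the read-out a long way. That step, however, concerns a different group, and nothing measured carries the 2-acetoxythiophen-3-yl group, so it sets no direction for compound 4.

In this assay compound 4 is therefore expected to give a number moving by a number 11.1 percentage points higher from compound 3 to compound 4 (beyond the scatter), a modest rise that stays close to the scatter. The estimate for compound 4 is 20%, with a range from 0% to 55%.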

Compound 4, percent growth inhibition at one concentration: 2.34%
Compound 4: middle estimate off by 17.7 percentage points, on the high side, and the stated range covers the measured number.
By their numbers in this assay, from the lowest: compounds 4, 3 and 1 (each within the scatter of the next, the first and the last beyond it); then compound 2.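

At the amide-type nitrogen, 2-acetoxythiophen-3-yl in place of 4-chlorophenyl gives a number 6.5 percentage points lower from compound 3 to compound 4 (within the scatter) in this assay, so the two compounds stand level. Before this result, the only step measured at this nitrogen was the large one, a number 57.8 percentage points higher from compound 1 to compound 2 (beyond the scatter), which was made on the 1,3-thiazol-2-yl compound. The new step shows that on the 1H-imidazol-2-yl compound, a five-membered ring carrying an acetoxy group can replace the six-membered chlorinated ring with no change beyond the scatter, although compound 3 at 8.86% and compound 4 at 2.34% both sit low on this read-out, and nothing at hand offers an explanation for this outcome.

From the compounds shown here alone, it remains open whether 2-chloro-5-(trifluoromethyl)phenyl on this nitrogen would lift the 1H-imidazol-2-yl compound as it lifted the 1,3-thiazol-2-yl one. Also open, going by these compounds, is whether the thiophene group would read differently with a hydroxyl group, an amine or a carboxylic acid in place of its acetoxy group.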